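Series notes: cyclohexyl on the ring amine nitrogen

The source may hold more compounds than are shown below. What is called first, only, known or untested is meant among the compounds shown, and "the series" means these compounds.

Measured so far:
compound 1 `Brc1ccc2ccn(CCN3CCNCC3)c2c1` — 61%
compound 2 `CC1CN(CCn2ccc3ccc(Br)cc32)CCN1` — 52%

Both numbers come from an assay on HEK293 cells for binding affinity to 5-hydroxytryptamine receptor 7 (Homo sapiens), read by radioligand binding, tested at 1 uM; a lower number here means less inhibition, a higher number more inhibition at the concentration tested (going by the name of the read-out). For the measured compounds named here, compound 1 gives the higher of the two numbers in this assay, with compound 2 as its only neighbour; the step of a number 9 percentage points lower from compound 1 to compound 2 (within the scatter), methyl in place of hydrogen on a saturated ring carbon, lies within the scatter, so the two compounds cannot be ordered on these data.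

Compound 3 `Brc1ccc2ccn(CCN3CCN(C4CCCCC4)CC3)c2c1` has not yet been tested in this assay. It differs from compound 1 by cyclohexyl in place of hydrogen on an amine nitrogen in a ring. Going by the values given here, no measured step touches this amine nitrogen; the only step known, a number 9 percentage points lower from compound 1 to compound 2 (within the scatter), concerns a saturated ring carbon and stays within the scatter, so it gives little guidance on a cyclohexyl entering at the ring nitrogen. The expected step of a number 11 percentage points lower from compound 1 to compound 3 (beyond the scatter) is therefore set near zero, with a wide range to reflect the missing precedent. The estimate for compound 3 in this assay is 50%, between 20% and 80%.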

Compound 3, a percentage reported as inhibition, at one concentration (the size of the read-out at that concentration, not a potency): 36%
The estimate for compound 3 lay 14 percentage points above the measured number; the measured number falls inside the stated range.
By their numbers in this assay, from the lowest: compound 3; then compounds 2 and 1 (each within the scatter of the next).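

In this assay, the amine nitrogen in the ring gives the only step shown so far that lies beyond the scatter: cyclohexyl in place of hydrogen there gives a number 25 percentage points lower from compound 1 to compound 3 (beyond the scatter), whereas methyl in place of hydrogen on a saturated ring carbon gives a number 9 percentage points lower from compound 1 to compound 2 (within the scatter). The change lowers the number without removing the read-out altogether, as compound 3 still gives 36% at the concentration tested. No data bearing on the reason for this step are available.

As far as these compounds go, a single group at this nitrogen does not show whether the step follows from the ring of carbon or from the count of 6 heavy atoms, so it remains open whether a methyl, an acetyl or a benzyl group at the same nitrogen would stay closer to compound 1. From the compounds shown here alone, it is also open whether cyclohexyl at this nitrogen would give a similar step on the methyl-bearing ring of compound 2, and whether a single number at one concentration reflects the order that full potency values would give.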